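The source may hold more compounds than are shown below. What is called first, only, known or untested is meant among the compounds shown, and "the series" means these compounds.

Three compounds share one core. In a functional assay (aorta) for antagonist activity, with Oryctolagus cuniculus as the target (a lower number here means a stronger inhibitor, a higher number a weaker inhibitor), compound 1 `CCCCc1cccc(=O)n1Cc1ccc(-c2ccccc2-c2nn[nH]n2)cc1` gives 4 nM. Compound 2 `CCCCc1ccc(CNC(=O)NC2CCCCC2)c(=O)n1Cc1ccc(-c2ccccc2-c2nn[nH]n2)cc1` gives 90 nM, and compound 3 `CCCCc1ccc(CN(C(C)C)S(C)(=O)=O)c(=O)n1Cc1ccc(-c2ccccc2-c2nn[nH]n2)cc1` gives 0.9 nM, the lowest number of the three, reached through a 4.4-fold lower number from compound 1 to compound 3 (0.65 log units; beyond the scatter) and a 100-fold lower number from compound 2 to compound 3 (2.00 log units; beyond the scatter). Compound 4 `CCCCc1ccc(CN(CC)S(C)(=O)=O)c(=O)n1Cc1ccc(-c2ccccc2-c2nn[nH]n2)cc1` differs from compound 3 in one place: hydrogen in place of methyl on a saturated chain carbon bound to a saturated chain carbon and a sulfonamide nitrogen. For the measured compounds named here, no measured step changes this group alone. The steps of a 4.4-fold lower number from compound 1 to compound 3 (0.65 log units; beyond the scatter) and a 100-fold lower number from compound 2 to compound 3 (2.00 log units; beyond the scatter) concern adding or exchanging the whole side chain, not removing the methyl from the group on the sulfonamide nitrogen, so they give no direct guide. A small step, probably within the usual scatter, is therefore expected, a 1.7-fold higher number from compound 3 to compound 4 (0.22 log units; within the scatter). Compound 4 is estimated to give about 1.5 nM, between 0.5 nM and 5 nM.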

Compound 4, half-maximal inhibitory concentration: 2 nM
Beside the measured number, compound 4's estimate is 1.3-fold (0.12 log units) below it; the measured number falls inside the stated range.
By their numbers in this assay, from the lowest: compound 3; then compounds 4 and 1 (each within the scatter of the next); then compound 2.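

In this assay, for the compounds shown here, the change from isopropyl to ethyl gives a 2.2-fold higher number from compound 3 to compound 4 (0.35 log units; beyond the scatter) and is the first sign that this single methyl counts, if only modestly. Going by these compounds alone, the ethyl side chain still stands far ahead of the (cyclohexylcarbamoyl)amino one, with a 45-fold lower number from compound 2 to compound 4 (1.65 log units; beyond the scatter) in that comparison, yet a 2.0-fold lower number from compound 1 to compound 4 (0.30 log units; within the scatter) leaves it level with plain hydrogen on the aromatic carbon, so a clear advantage over hydrogen is seen only with isopropyl. Nothing available explains this. Still open, as far as these compounds go, is how a methyl, a longer chain such as butyl or a cyclopropyl ring on the sulfonamide nitrogen would compare.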